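Extending the Hydroxycarbamoyl Chain of Compound 1

The source may hold more compounds than are shown below. What is called first, only, known or untested is meant among the compounds shown, and "the series" means these compounds.

In a functional assay on MCF7 cells (Homo sapiens) for inhibition, read by MTT assay, with a stated time of 72 h (on this read-out higher numbers stand for weaker inhibition and lower numbers for stronger inhibition), compound 1 `Nc1nc2cc(-c3nn(CCCC(=O)NO)c4ncnc(N)c34)ccc2o1` gives > 50000 nM, which is a limit and not a number. Compound 2 `Nc1ncnc2c1c(-c1cnc3[nH]ccc3c1)nn2CCCCC(=O)NO` also reaches only a limit, > 150000 nM. On a different core from compound 1, compound 3 `Nc1ncnc2c1c(-c1cnc3[nH]ccc3c1)nn2CCCCCCC(=O)NO` gives a true number, 19800 nM.

Compound 4 `Nc1nc2cc(-c3nn(CCCCCCCCC(=O)NO)c4ncnc(N)c34)ccc2o1` keeps the core of compound 1 and carries a longer chain: 5-(hydroxycarbamoyl)pentyl in place of hydroxycarbamoyl on a saturated chain carbon, three bonds along the chain from an aromatic nitrogen. In words, 5-(hydroxycarbamoyl)pentyl stands in place of hydroxycarbamoyl.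

Going by the values given here, only one measured step bears on this change: an at least 7.5-fold lower number from compound 2 to compound 3 (0.87 log units; beyond the scatter). It is beyond the scatter, but it starts from a limit, it belongs to the other core, and it adds a shorter piece of chain. The data hold no measured chain extension on the core of compound 1, so the transfer is uncertain. A lower number is therefore expected, with a step somewhat larger than that one.

The expected change is an at least 12-fold lower number from compound 1 to compound 4 (1.09 log units; beyond the scatter), and this size is an estimate.

For compound 4 the estimated value is 4000 nM, with an expected range from 500 nM to 30000 nM.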

Compound 4, half-maximal inhibitory concentration: 42100 nM
Compound 4: middle estimate off by 11-fold (1.02 log units), on the low side; the whole stated range lies below it.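

In this assay, going by these compounds alone, the longer chain on the core of compound 1 gives an at least 1.1-fold lower number from compound 1 to compound 4 (0.07 log units; that floor lies within the scatter), and this is the first chain extension on that core with a step attached. Compound 4 also gives this core a true number, whereas the earlier compound on it reached only a limit. On these data alone, the step is only a floor, and the true size of the change stays unknown because compound 1 stands at a limit: the limit of > 50000 nM in this assay, at which 1 of the 4 values shown sits.

What the compounds shown leave open is how a chain of intermediate length, such as 3-(hydroxycarbamoyl)propyl, would read on the core of compound 1. Also open, as far as these compounds go, is whether a carboxylic acid at the end of the 5-(hydroxycarbamoyl)pentyl chain, in place of the hydroxycarbamoyl group, would give a lower or a higher number.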